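This account rests on a few compounds, and the source may have more. Where it says the series, first, only, none or still open, it means among the compounds named here.

Compound 3 `COc1ccc(-n2ccc(=O)c(C(=O)Nc3ccc(Oc4ccnc5c4ccn5C)cc3)n2)cc1` stands at the edge of what the measurement can report: in a functional assay on A549 cells (Homo sapiens) for cytotoxicity, read by MTT assay, with a stated time of 72 h (a higher number here means a weaker inhibitor, a lower number a stronger inhibitor), compound 3 gives > 60000 nM, a limit rather than a number. Its parent, compound 1 `COc1ccc(-n2ccc(=O)c(C(=O)Nc3ccc(Oc4ccnc5[nH]ccc45)cc3)n2)cc1`, gives 53100 nM in this assay. Compound 2 `COc1ccc(-n2ccc(=O)c(C(=O)Nc3ccc(Oc4ccnc5[nH]ccc45)c(F)c3)n2)cc1` gives > 60000 nM in this assay, again a limit. The two measured steps, an at least 1.1-fold higher number from compound 1 to compound 2 (0.05 log units; that floor lies within the scatter) and an at least 1.1-fold higher number from compound 1 to compound 3 (0.05 log units; that floor lies within the scatter), both lie within the scatter, and both sit on (the limit of > 60000 nM in this assay, at which 2 of the 3 values shown sit). Compound 4 `Cn1ccc2c(Oc3ccc(NC(=O)c4nn(-c5ccc(Br)cc5F)ccc4=O)cc3)ccnc21` differs from compound 3 by 4-bromo-2-fluorophenyl in place of 4-methoxyphenyl on an aromatic nitrogen. Neither measured step touches that group, so no change beyond the scatter is expected for compound 4, and the expected step of a number no higher from compound 3 to compound 4 (the limit leaves the size open) stays within the scatter. Compound 4 is therefore estimated at 60000 nM in this assay, within 20000 nM to 150000 nM.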

Compound 4, half-maximal inhibitory concentration: 35700 nM
The estimate for compound 4 lay 1.7-fold (0.23 log units) above the measured number, within the range that was stated.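

The exchange of 4-methoxyphenyl for 4-bromo-2-fluorophenyl on the aromatic nitrogen gives, in this assay, an at least 1.6-fold lower number from compound 3 to compound 4 (0.22 log units; that floor lies within the scatter). Within the data shown here, this is the first change at this position, and it leaves compound 4 with a measured number where compound 3 has only a limit. The true size of the step stays unknown because it starts from that limit: the limit of > 60000 nM in this assay, at which 2 of the 4 values shown sit.

The compounds shown do not separate the bromine from the fluorine, which enter together. They also leave open whether an amine or a carboxylic acid in place of the bromine would give a step beyond the scatter.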